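The source may hold more compounds than are shown below. What is called first, only, known or untested is meant among the compounds shown, and "the series" means these compounds.

Compound 3 (`CCCCCCCCCCCCOC(=O)CCC(=O)N1CCN(CCCOc2cc3c(Nc4ccc(F)c(Cl)c4)ncnc3cc2OC)CC1`) gives the lowest number of the three measured compounds in a functional assay on A549 cells (Homo sapiens) for cytotoxicity, read by MTT assay, with a stated time of 24 h, tested at 40 uM (on this read-out higher numbers stand for a weaker effect at the one concentration tested and lower numbers for a stronger effect), with a read-out of 5.7% at the one concentration tested. Compound 2 (`CCCCCCCCCOC(=O)CCC(=O)N1CCN(CCCOc2cc3c(Nc4ccc(F)c(Cl)c4)ncnc3cc2OC)CC1`) gives 17.9% and compound 1 (`CCCCCCOC(=O)CCC(=O)N1CCN(CCCOc2cc3c(Nc4ccc(F)c(Cl)c4)ncnc3cc2OC)CC1`) gives 74.2% in this assay as well. Compound 4 (`CCCCCCCCCCCCCCOC(=O)CCC(=O)N1CCN(CCCOc2cc3c(Nc4ccc(F)c(Cl)c4)ncnc3cc2OC)CC1`) has not been measured; its difference from compound 3 is ethyl in place of hydrogen on a saturated chain carbon, ten or more bonds along the chain from an oxygen next to a carbonyl group. Lengthening this same chain has been followed twice: a number 56.3 percentage points lower from compound 1 to compound 2 (beyond the scatter) and a number 12.2 percentage points lower from compound 2 to compound 3 (beyond the scatter), adding up to a number 68.5 percentage points lower from compound 1 to compound 3 (beyond the scatter). Because a number 12.2 percentage points lower from compound 2 to compound 3 (beyond the scatter) was already modest and compound 3 gives 5.7% close to the bottom of the scale, only a small downward step or none beyond the scatter is expected in this assay, estimated as a number 1.7 percentage points lower from compound 3 to compound 4 (within the scatter). Compound 4 is therefore expected to give about 4% in this assay, within a range from 0% to 12%.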

Compound 4, a percentage reported as activity, at one concentration (the size of the read-out at that concentration, not a potency): 88.6%
Beside the measured number, compound 4's estimate is 84.6 percentage points below it; measured number outside the range, above it.
By their numbers in this assay, from the lowest: compound 3; then compound 2; then compound 1; then compound 4.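

Lengthening this chain does not keep lowering the number: ethyl added at this far end reverses the earlier fall in this assay, with a number 82.9 percentage points higher from compound 3 to compound 4 (beyond the scatter) as a sharp turn after a run of drops. The other comparisons, a number 70.7 percentage points higher from compound 2 to compound 4 (beyond the scatter) and a number 14.4 percentage points higher from compound 1 to compound 4 (beyond the scatter), place the longest chain shown above even the shortest, so the stronger effect holds only over a limited range of chain lengths. Nothing measured here explains this reversal.

Going by these compounds, whether a still longer chain keeps the number high remains open. So does what a chain ending in an amine or a carboxylic acid would give at this position.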